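Amide to urea change in the series: working notes

The source may hold more compounds than are shown below. What is called first, only, known or untested is meant among the compounds shown, and "the series" means these compounds.

Compound 2 `COc1cc(-c2nn(-c3cccc(NC(=O)c4ccc(Cl)c(C(F)(F)F)c4)c3)cc2-c2ccncc2)ccc1Cl` gives 6140 nM in a functional assay on COLO 205 cells (Homo sapiens) for inhibition, read by sulforhodamine B assay, with a stated time of 48 h (on this read-out lower numbers stand for stronger inhibition of growth and higher numbers for weaker inhibition of growth), the higher of the two numbers recorded so far. Going by the values given here, compound 1 `COc1cc(-c2nn(-c3cccc(NC(=O)c4cccc(C(F)(F)F)c4)c3)cc2-c2ccncc2)ccc1Cl` gives 1640 nM in this assay; the single measured step is a 3.7-fold higher number from compound 1 to compound 2 (0.57 log units; beyond the scatter), a change on an aromatic carbon. Compound 3 `COc1cc(-c2nn(-c3cccc(NC(=O)Nc4ccc(Cl)c(C(F)(F)F)c4)c3)cc2-c2ccncc2)ccc1Cl` differs from compound 2 by (4-chloro-3-(trifluoromethyl)phenyl)amino in place of 4-chloro-3-(trifluoromethyl)phenyl on a carbonyl carbon. Among the compounds with values here, no measured step concerns the carbonyl carbon, so nothing recorded points in either direction. Compound 3 is expected to give about 4000 nM, range 1000 nM to 16000 nM. The expected step is a 1.5-fold lower number from compound 2 to compound 3 (0.19 log units; within the scatter), not beyond the scatter.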

Compound 3, concentration for 50% growth inhibition: 711 nM
Beside the measured number, compound 3's estimate is 5.6-fold (0.75 log units) above it; measured number outside the range, below it.
By their numbers in this assay, from the lowest: compound 3; then compound 1; then compound 2.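

On the carbonyl carbon, (4-chloro-3-(trifluoromethyl)phenyl)amino in place of 4-chloro-3-(trifluoromethyl)phenyl gives, in this assay, an 8.6-fold lower number from compound 2 to compound 3 (0.94 log units; beyond the scatter), so this position can shift growth inhibition beyond the scatter. The same position also carries compound 3 past the unchlorinated amide, with a 2.3-fold lower number from compound 1 to compound 3 (0.36 log units; beyond the scatter). No evidence bears on why this change lowers the number.

Open is whether the amino nitrogen itself is what matters, since a methylene or an ether oxygen on the carbonyl carbon does not appear among the compounds shown. Also open, from the compounds shown here alone, is whether 3-(trifluoromethyl)phenyl)amino, lacking the chloro, would behave alike.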